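From methoxy to hydroxy on compound 2

A few compounds are considered here, and "the series" means these few. Any claim that something is new, unique, unknown or untested is made for them only; others in the source may bear on it.

Within the data shown here, the series so far holds two measured members, compound 1 (`COc1ccc(C(=O)c2cc3cc(O)c(OC)cc3o2)cc1`) and compound 2 (`COc1ccc(C(=O)c2cc3cc(OC)c(O)cc3o2)cc1`). In a functional assay on RAW264.7 cells (Mus musculus) for inhibition, read by Griess assay, with a stated time of 18 h (a higher number here means a weaker inhibitor, a lower number a stronger inhibitor), compound 1 gives 10800 nM and compound 2 gives 13300 nM. Compound 2 thus stands within the scatter of compound 1, and neither ranks ahead of the other. Next comes compound 3 (`COc1ccc(C(=O)c2cc3cc(O)c(O)cc3o2)cc1`), not yet measured in this assay. It differs from compound 2 by hydrogen in place of methyl on an oxygen on an aromatic ring, methoxy to hydroxy: hydrogen in place of methyl on an oxygen on an aromatic ring. Among the measured compounds shown here, no measured pair differs in one place alone, so the data offer no step against which to scale this one. The expectation is correspondingly loose: a modest step toward a lower number, meaning a stronger inhibitor, only a little beyond the scatter, with no real change still possible. The expected move is a 2.2-fold lower number from compound 2 to compound 3 (0.35 log units; beyond the scatter). For compound 3 the estimated value is 6000 nM, with an expected range from 2000 nM to 15000 nM.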

Compound 3, half-maximal inhibitory concentration: 1900 nM
Beside the measured number, compound 3's estimate is 3.2-fold (0.50 log units) above it; the measured number lies below the stated range.
By their numbers in this assay, from the lowest: compound 3; then compounds 1 and 2 (each within the scatter of the next).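

In this assay, the change from methoxy to hydroxy, hydrogen in place of methyl on an oxygen on an aromatic ring, gives a 7.0-fold lower number from compound 2 to compound 3 (0.85 log units; beyond the scatter), and the same change at the other oxygen of the shared core gives a 5.7-fold lower number from compound 1 to compound 3 (0.75 log units; beyond the scatter), both beyond the scatter. Compounds 1 and 2 each keep one such methyl and alone could not show this; compound 3 shows that the number falls when either of these methyl groups gives way to hydrogen, so the step does not belong to one oxygen only. Nothing available bears on why removing the methyl has this effect.

The series leaves open whether the lower number in compound 3 requires hydroxy on both oxygens or would survive replacing one of them with an amine, a fluorine or an ethoxy group. The one methoxy left in compound 3 is also an open point, since its exchange for hydroxy, or for a longer chain such as propoxy, has no reading in the compounds shown.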